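Trifluoromethyl to Isopropyl: What Compound 4 Might Show

The source may report more compounds than this note shows. Statements on the series, on what has been measured and on what is new or still open speak of the compounds shown alone.

Compound 1, `CNC(=O)c1ccccc1Oc1nc(Nc2ccccc2OC)ncc1Br`, in a functional assay on MCF7 cells (Homo sapiens) for antiproliferative activity, read by MTT assay, with a stated time of 24 h; a higher number here means a weaker inhibitor, a lower number a stronger inhibitor: > 50000 nM, a limit.
Compound 2, `CNC(=O)c1ccccc1Oc1nc(Nc2ccc(Cl)cc2F)ncc1Br`, in this assay: > 50000 nM, a limit.
Compound 3, `CNC(=O)c1ccccc1Oc1nc(Nc2cccc(C(F)(F)F)c2)ncc1Br`, in this assay: 57800 nM.

Compound 3 is the only one of the three to return a number; the other two sit at the limit of > 50000 nM in this assay, at which 2 of the 3 values shown sit. Among the compounds with values here, the one change between measured compounds, a step that the two limits leave unreadable from compound 1 to compound 2, cannot be read, as both ends are limits. Compound 4, `CNC(=O)c1ccccc1Oc1nc(Nc2cccc(C(C)C)c2)ncc1Br`, differs from compound 3 in one place: isopropyl in place of trifluoromethyl on an aromatic carbon. Within the data shown here, no measured step compares an alkyl with a trifluoromethyl at this place, so there is nothing among the data to point in either direction, and the step from compound 3 to compound 4 is expected to be a 1.2-fold lower number from compound 3 to compound 4 (0.06 log units; within the scatter), that is, none beyond the scatter. Compound 4 is therefore estimated at 50000 nM in this assay, with a range from 20000 nM to 120000 nM, and a real chance that the assay returns only a limit.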

Compound 4, half-maximal inhibitory concentration: 26500 nM
Beside the measured number, compound 4's estimate is 1.9-fold (0.28 log units) above it; low and high end bracket the measured number.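

In this assay this aromatic carbon gives the first readable step among these compounds: isopropyl in place of trifluoromethyl brings a 2.2-fold lower number from compound 3 to compound 4 (0.34 log units; beyond the scatter) at this place, a modest change. With 3-isopropylphenyl on the nitrogen, replacing 4-chloro-2-fluorophenyl gives an at least 1.8-fold lower number from compound 2 to compound 4 (0.27 log units; that floor lies within the scatter) and replacing 2-methoxyphenyl gives an at least 1.8-fold lower number from compound 1 to compound 4 (0.27 log units; that floor lies within the scatter) in the same assay. Those two steps are floors only, because their starting compounds stand at a limit: the limit of > 50000 nM in this assay, at which 2 of the 4 values shown sit.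

The compounds shown leave open whether a tert-butyl group, a longer chain or an amine at this aromatic carbon would move the number further in this assay or back again. They also leave open how far compound 1 and compound 2 lie from compound 4 beyond those floors.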